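This account rests on a few compounds, and the source may have more. Where it says the series, first, only, none or still open, it means among the compounds named here.

- compound 1 (`COc1ccc(-c2cc(Cl)c3c(N)ncnn23)cc1N1CCN(C(C)=O)C(C)(C)C1=O`): 94%
- compound 2 (`CC(=O)N1CCN(c2cc(-c3cc(Cl)c4c(N)ncnn34)ccc2S(C)(=O)=O)C(=O)C1(C)C`): 84%

In an ADME assay on microsomes from liver (Mus musculus) for metabolic stability, read by LC-MS, using NADPH, with stated times of 6 min and 10 min, tested at 0.5 uM (a higher number here means that more of the compound is left, a lower number that less of the compound is left), compound 2 (84%) stands within the scatter of compound 1 (94%). Compound 3 (`CC(=O)N1CCN(c2cc(-c3cc(Cl)c4c(N)ncnn34)ccc2C(C)O)C(=O)C1(C)C`) carries 1-hydroxyethyl in place of methylsulfonyl on an aromatic carbon. Going by the values given here, only one measured step bears on this, a number 10 percentage points lower from compound 1 to compound 2 (within the scatter), a swap of methoxy for methylsulfonyl on an aromatic carbon. Among the compounds with values here, no measured step involves 1-hydroxyethyl, so the guide is weak. The expected change, a number 4 percentage points lower from compound 2 to compound 3 (within the scatter), is no step beyond the scatter in this assay. Compound 3 is estimated at 80% (range 60% to 95%).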

Compound 3, percent of the compound remaining: 100%
Beside the measured number, compound 3's estimate is 20 percentage points below it; measured number above the stated range.
By their numbers in this assay, from the lowest: compounds 2, 1 and 3 (each within the scatter of the next, the first and the last beyond it).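

At this aromatic carbon, this assay now gives a step beyond the scatter, though a modest one: with 1-hydroxyethyl in place of methylsulfonyl, it reads a number 16 percentage points higher from compound 2 to compound 3 (beyond the scatter) for this change. Methoxy and 1-hydroxyethyl at the same carbon cannot be told apart, since the reading of a number 6 percentage points higher from compound 1 to compound 3 (within the scatter) stays within the scatter. Nothing at hand gives a reason for either step. The compounds shown leave open how an amine, a carboxylic acid or a longer chain at this carbon would read in this assay and whether any such group would stand apart from methoxy and 1-hydroxyethyl.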